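This account rests on a few compounds, and the source may have more. Where it says the series, first, only, none or still open, it means among the compounds named here.

Working notes on the series in a functional assay on PC-12 cells (Rattus norvegicus) for cytotoxicity, read by MTT assay, with stated times of 2 h and 24 h, tested at 5 uM; on this read-out higher numbers stand for a stronger effect at the one concentration tested and lower numbers for a weaker effect.

Two compounds of the shared core have been run so far. Compound 1 `COc1cccc(-n2nc(-c3ccc(C(F)(F)F)cc3O)nc2-c2ccccc2O)c1` gives 96.8% in this assay. For the measured compounds named here, compound 2 `Oc1cc(C(F)(F)F)ccc1-c1nc(-c2ccccc2O)n(-c2ccc(F)cc2F)n1` gives 83.5% in this assay, which puts compound 2 at the lower of the two numbers in hand, with compound 1 as its only neighbour. Going by the values given here, the single measured step is a number 13.3 percentage points lower from compound 1 to compound 2 (beyond the scatter), so exchanging the group on the aromatic nitrogen has so far moved the read-out by a modest amount.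

Compound 3 `Oc1cc(C(F)(F)F)ccc1-c1nc(-c2ccccc2O)n(-c2ccc(Cl)cc2Cl)n1` is the next member and is not yet measured. It differs from compound 2 in one place: 2,4-dichlorophenyl in place of 2,4-difluorophenyl on an aromatic nitrogen. Among the compounds with values here, no measured step compares a 2,4-dichlorophenyl with a 2,4-difluorophenyl on that aromatic nitrogen, so the one step that bears on it is only the general one from compound 1 to compound 2, and that was modest. A step no larger than that, in either direction, is therefore expected, and a change of a number 0.5 percentage points higher from compound 2 to compound 3 (within the scatter) is estimated for compound 3. For compound 3 in this assay a value of 84% is expected, within a range from 68% to 98%.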

Compound 3, a percentage reported as activity, at one concentration (the size of the read-out at that concentration, not a potency): 86.7%
Compound 3: middle estimate off by 2.7 percentage points, on the low side; the range from low to high includes it.
By their numbers in this assay, from the lowest: compounds 2 and 3 (each within the scatter of the next); then compound 1.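

In this assay, for the compounds shown here, the first comparison of two halogen-bearing groups on the aromatic nitrogen gives a number 3.2 percentage points higher from compound 2 to compound 3 (within the scatter), so at this position 2,4-dichlorophenyl and 2,4-difluorophenyl cannot be told apart, and exchanging fluorine for chlorine at both sites leaves the read-out unresolved. The second step, a number 10.1 percentage points lower from compound 1 to compound 3 (beyond the scatter), shows that the separation first seen for 2,4-difluorophenyl against 3-methoxyphenyl also holds for 2,4-dichlorophenyl, since both compounds with two halogens on that ring stand beyond the scatter from compound 1, with no compound shown going against this. Nothing measured here offers an explanation for either step.

The compounds shown leave open whether the separation from compound 1 follows the methoxy group itself or the halogens, a question that a plain phenyl group on the same nitrogen would help to settle. Also open, from the compounds shown here alone, is how the read-out responds on that nitrogen to an aromatic ring carrying an amine or a carboxylic acid, and with one concentration tested, the numbers say nothing about potency.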